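Aryl Swap on the Carbonyl Carbon: Toward Compound 4

The source may report more compounds than this note shows. Statements on the series, on what has been measured and on what is new or still open speak of the compounds shown alone.

Three measured compounds share one core and differ only in the aryl group on the carbonyl carbon and in the substitution of the other aryl. Compound 1 `COc1ccc(-c2cc(/C=C/C(=O)c3ccc(N)cc3)[nH]n2)cc1` carries a 4-aminophenyl on the carbonyl carbon, and in a functional assay on MDA-MB-468 cells (Homo sapiens) for cytotoxicity, read by sulforhodamine B assay, with a stated time of 48 h, tested at 0.1 uM (a higher number here means a weaker effect of the compound at the concentration tested, a lower number a stronger effect), compound 1 gives 86%. Compound 2 `COc1cc(-c2cc(/C=C/C(=O)c3ccc(N)cc3)[nH]n2)cc(OC)c1OC` keeps that 4-aminophenyl; in this assay compound 2 gives 83%. Compound 3 `COc1cc(-c2cc(/C=C/C(=O)c3ccc(Cl)c(Cl)c3)[nH]n2)cc(OC)c1OC` carries a 3,4-dichlorophenyl on the carbonyl carbon, and in this assay compound 3 gives 91%, the highest of the three numbers, although both gaps, to compound 1 and to compound 2, fall within the scatter, so the three are not separable. Within the data shown here, the single step that swaps the aryl on the carbonyl carbon, a number 8 percentage points higher from compound 2 to compound 3 (within the scatter), is likewise within the scatter.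

Compound 4 `COc1ccc(C(=O)/C=C/c2cc(-c3cc(OC)c(OC)c(OC)c3)n[nH]2)cc1` follows from compound 3 by the change (4-methoxyphenyl in place of 3,4-dichlorophenyl on a carbonyl carbon). Among the measured compounds shown here, no measured compound carries a 4-methoxyphenyl on the carbonyl carbon, so the only step that bears on the change is a number 8 percentage points higher from compound 2 to compound 3 (within the scatter), which shows an aryl exchange at that position moving the number no further than the scatter. The expected step of a number 4 percentage points lower from compound 3 to compound 4 (within the scatter) is accordingly one of no size beyond the scatter. Compound 4 is estimated at 87%, with a range from 74% to 98%.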

Compound 4, a percentage reported as activity, at one concentration (the size of the read-out at that concentration, not a potency): 88%
For compound 4 the middle estimate is 1 percentage points below the measured one; the range from low to high includes it.
By their numbers in this assay, from the lowest: compounds 2, 1, 4 and 3 (each within the scatter of the next).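

Working notes on the aryl position: in this assay, replacing 3,4-dichlorophenyl with 4-methoxyphenyl on the carbonyl carbon gives a number 3 percentage points lower from compound 3 to compound 4 (within the scatter), even though chlorine gives way to oxygen and the entering group carries 1 hydrogen-bond acceptor where the leaving group carries 0. The comparison with the amino compound gives a number 5 percentage points higher from compound 2 to compound 4 (within the scatter), so 4-aminophenyl, 3,4-dichlorophenyl and 4-methoxyphenyl now form a set of three groups at this position, with the other aryl held constant, and none of the three can be separated from the others in this read-out. No supporting measurement offers a reason for this lack of separation.

Still open, on these data alone, is whether the position can move the number at all, since these three neutral aryl groups on the shared core span only steps within the scatter at the single concentration tested. A carboxylic acid on the aryl ring, a longer chain in place of the methoxy, or a morpholine at this position could test that, as could a comparison of the same aryl groups at a higher concentration.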